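This account rests on a few compounds, and the source may have more. Where it says the series, first, only, none or still open, it means among the compounds named here.

Compound 1 `CC(=O)c1cccc(-c2sc(N)c(C(=O)c3ccccc3)c2-c2cccc(C(F)(F)F)c2)c1` gives 33.1% in an assay on CHO-K1 cells for displacement of a labelled ligand from adenosine receptor A1 (Homo sapiens), tested at 10 uM; a higher number here means more inhibition at the concentration tested (going by the name of the read-out), a lower number less inhibition. Compound 2 `CC(=O)c1ccc(-c2sc(N)c(C(=O)c3ccccc3)c2-c2cccc(C(F)(F)F)c2)cc1` gives 25.6% in this assay, and the step of a number 7.5 percentage points lower from compound 1 to compound 2 (within the scatter) leaves the two numbers within the scatter of each other, so neither stands apart. Compound 3 `Nc1sc(-c2ccc(Cl)cc2)c(-c2cccc(C(F)(F)F)c2)c1C(=O)c1ccccc1` carries the change (chloro in place of acetyl on an aromatic carbon). For the measured compounds named here, no measured step concerns this change; the only step known, from compound 1 to compound 2, moves an acetyl and was within the scatter, so it gives no direction. The step of a number 0.6 percentage points lower from compound 2 to compound 3 (within the scatter) is therefore expected to lie within the scatter, with a wide uncertainty. Compound 3 is estimated at 25%, range 5% to 50%.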

Compound 3, a percentage reported as inhibition, at one concentration (the size of the read-out at that concentration, not a potency): 59.1%
Compound 3: the middle estimate sits 34.1 percentage points below what was measured; measured number outside the range, above it.
By their numbers in this assay, from the lowest: compounds 2 and 1 (each within the scatter of the next); then compound 3.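

At this position on the aromatic ring, the group carried matters in this assay, which moving the acetyl had not shown: chloro in place of acetyl gives a number 33.5 percentage points higher from compound 2 to compound 3 (beyond the scatter). The comparison with the other acetyl compound, 4-chlorophenyl in place of 3-acetylphenyl, gives a number 26 percentage points higher from compound 1 to compound 3 (beyond the scatter), so compound 3 stands apart from both. Nothing measured here bears on what lies behind these steps.

Still open, on these data alone, is whether the higher number is particular to chloro or follows from the loss of the acetyl. An amine, a carboxylic acid or a methoxy group at this position would separate the two readings.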